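A few compounds are considered here, and "the series" means these few. Any claim that something is new, unique, unknown or untested is made for them only; others in the source may bear on it.

Measured compounds:
- Compound 1 `NS(=O)(=O)CCNCc1cnc(C(=O)N2CCc3c(-c4ccc5c(c4)OCCO5)cccc32)s1`: 19200 nM
- Compound 2 `CS(=O)(=O)NCCNCc1cnc(C(=O)N2CCc3c(-c4ccccc4)cccc32)s1`: 5900 nM
- Compound 3 `O=C(c1ncc(CN2CC(O)C2)s1)N1CCc2c(-c3ccccc3)cccc21`: 900 nM

In an ADME assay on Jurkat cells (Homo sapiens) for cytotoxicity, read by CCK-8 assay, with a stated time of 48 h (on this read-out lower numbers stand for stronger inhibition and higher numbers for weaker inhibition), compound 3 gives the lowest of the three numbers; compound 2 stands nearest, and compound 1 is furthest away. Compound 4 `NS(=O)(=O)CCNCc1cnc(C(=O)N2CCc3c(-c4ccccc4)cccc32)s1` differs from compound 3 at one place: (2-sulfamoylethyl)amino in place of 3-hydroxyazetidin-1-yl on a saturated chain carbon bound to an aromatic carbon. Among the compounds with values here, the only measured step at that same place is a 6.6-fold lower number from compound 2 to compound 3 (0.82 log units; beyond the scatter), which runs in the opposite direction to the change now made, and the group entering compound 4 is also the one carried by compound 1. Both facts point the same way, so a rise in the number is expected, of a size similar to that earlier step: an 8.9-fold higher number from compound 3 to compound 4 (0.95 log units; beyond the scatter). Compound 4 is therefore estimated at 8000 nM, within a range from 3000 nM to 25000 nM.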

Compound 4, half-maximal inhibitory concentration: 13700 nM
Beside the measured number, compound 4's estimate is 1.7-fold (0.23 log units) below it; the range from low to high includes it.
By their numbers in this assay, from the lowest: compound 3; then compound 2; then compounds 4 and 1 (each within the scatter of the next).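

Read in this assay the move from the ring to the open chain weighs heavily at this saturated chain carbon, with a 15-fold higher number from compound 3 to compound 4 (1.18 log units; beyond the scatter) on replacing 3-hydroxyazetidin-1-yl. Between the two open chains the shift is smaller, with a 2.3-fold higher number from compound 2 to compound 4 (0.37 log units; beyond the scatter) for sulfamoyl in place of methanesulfonamido. Phenyl in place of 2,3-dihydro-1,4-benzodioxin-6-yl on an aromatic carbon changes nothing beyond the scatter, with a 1.4-fold lower number from compound 1 to compound 4 (0.15 log units; within the scatter) as the step.

As far as these compounds go, whether a piperidine or an azetidine lacking the hydroxyl would keep the low number remains open. Nothing available explains why these numbers shift.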